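Methoxy for Fluoro: Expected Half-Life of Compound 4

The source may hold more compounds than are shown below. What is called first, only, known or untested is meant among the compounds shown, and "the series" means these compounds.

Measured compounds:
Compound 1, `C=CC(=O)N1CC(NC(=O)Cn2c(C3CC3)c(C(=O)N3CCc4c(cccc4OC)C3)c3cc(Br)ccc32)C1`: 1.67 h
Compound 2, `C=CC(=O)N1CC(NC(=O)Cn2cc(C(=O)N(C)Cc3ccccc3)c3cc(Br)ccc32)C1`: 1.67 h
Compound 3, `C=CC(=O)N1CC(NC(=O)Cn2cc(C(=O)N3CCc4c(F)cccc4C3)c3cc(Br)ccc32)C1`: 1.67 h

In a physicochemical assay for pharmacokinetics, read by LC-MS, in phosphate buffer, at pH 7.4, in the presence of a further agent that is not named here (a lower number here means that the compound disappears faster, a higher number that the compound lasts longer), compound 3 gives 1.67 h. On this number compound 3 stands level with compounds 1 and 2; its nearest neighbour is compound 1 and its furthest is compound 2, and both gaps fall within the scatter. Going by the values given here, the only measured step that changes one place is no change at the digits printed from compound 2 to compound 3 (within the scatter), which came with 5-fluoro-1,2,3,4-tetrahydroisoquinolin-2-yl in place of benzyl(methyl)amino on a carbonyl carbon; the read-out did not move.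

Compound 4, `C=CC(=O)N1CC(NC(=O)Cn2cc(C(=O)N3CCc4c(cccc4OC)C3)c3cc(Br)ccc32)C1`, differs from compound 3 by methoxy in place of fluoro on an aromatic carbon. Among the compounds with values here, no measured pair isolates this change. Compound 1, however, already carries the methoxy group on the same kind of ring, alongside further differences elsewhere, and in this assay compound 1 gives 1.67 h. Since every measured compound, whatever its substituent on that ring, sits at the same value within the scatter, the step for compound 4 is expected to be none beyond the scatter, namely no change at the digits printed from compound 3 to compound 4 (within the scatter). Compound 4 is therefore estimated to give 1.67 h in this assay, with an expected range from 0.9 h to 3.2 h.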

Compound 4, half-life: 1.67 h
Estimate against measurement, compound 4: no gap at the digits printed; measured number inside the range.
By their numbers in this assay, from the lowest: compounds 1, 2, 3 and 4 (each within the scatter of the next).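

In this assay, going by these compounds alone, compound 4 gives the first direct reading of methoxy in place of fluoro on this aromatic carbon, and the exchange leaves the half-life level (no change at the digits printed from compound 3 to compound 4 (within the scatter)). It also separates a second place from this one, since hydrogen in place of cyclopropyl on an aromatic carbon of the shared core shows no measurable effect (no change at the digits printed from compound 1 to compound 4 (within the scatter)), and the group on the carbonyl carbon can be exchanged for the methoxy-bearing ring system with the same outcome (no change at the digits printed from compound 2 to compound 4 (within the scatter)). Nothing available explains why the read-out stays the same across these exchanges.

All four compounds share one value in this assay, so the compounds shown do not reveal which structural features, if any, influence the half-life. As far as these compounds go, it remains open whether an amine or a carboxylic acid on this aromatic carbon, or a nitrile in place of the bromo group on the shared core, would give a value beyond the scatter.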